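From compound 2 to compound 3: one added hydroxy

The source may report more compounds than this note shows. Statements on the series, on what has been measured and on what is new or still open speak of the compounds shown alone.

In an ADME assay on PC-12 cells (Rattus norvegicus) for cytotoxicity, read by WST assay, with a stated time of 24 h (a higher number here means that more compound is tolerated, a lower number that less compound is tolerated), compound 2 (`O=C(/C=C/c1cccc(O)c1)/C=C/c1ccc(O)c(O)c1`) gives > 100000 nM as a limit of the assay and not a number. Its exact standing is therefore unknown. Compound 3 (`O=C(/C=C/c1ccc(O)c(O)c1)/C=C/c1cc(O)ccc1O`) differs from it by a single change, hydroxy in place of hydrogen on an aromatic carbon and the new hydroxy sits ortho to a large group and para to a hydroxy group. Within the data shown here, one measured step bears on this change. The step of an at least 2.9-fold higher number from compound 1 to compound 2 (0.46 log units; beyond the scatter) came with 3-hydroxyphenyl in place of 2-hydroxyphenyl. Compound 3 again carries a hydroxy ortho to a large group, as does compound 1 (`O=C(/C=C/c1ccc(O)c(O)c1)/C=C/c1ccccc1O`) with 34000 nM as its value. A move of similar size towards a lower number is therefore expected, estimated as an at least 2.8-fold lower number from compound 2 to compound 3 (0.45 log units; beyond the scatter) on this single comparison. In this assay the estimate for compound 3 is 35000 nM with an expected range from 10000 nM to 100000 nM for the coming measurement.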

Compound 3, half-maximal cytotoxic concentration: 39000 nM
Beside the measured number, compound 3's estimate is 1.1-fold (0.05 log units) below it; the range from low to high includes it.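

In this assay, the added hydroxy, ortho to a large group and para to a hydroxy group, moves the result off the limit of the assay, with an at least 2.5-fold lower number from compound 2 to compound 3 (0.40 log units; beyond the scatter). The hydroxy that compound 3 carries in addition to those of compound 1 makes no difference that can be told from the scatter, with a 1.1-fold higher number from compound 1 to compound 3 (0.06 log units; within the scatter), so both compounds with a hydroxy ortho to a large group stand apart from compound 2, which has none there. Compound 2 gives a limit of the assay and not a number, so its step marks only a bound: the limit of > 100000 nM in this assay, at which 1 of the 3 values shown sits.

Going by these compounds, how far compound 2 truly lies from compound 3 stays open. Also open, on these data alone, is whether a methoxy group, a fluorine or an amine at this same place would go with a similarly low number.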